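Trading a dichlorobenzyl group for a fluorobenzyl group

The source may hold more compounds than are shown below. What is called first, only, known or untested is meant among the compounds shown, and "the series" means these compounds.

Compound 1 `Clc1ccc(COc2ccccc2/C=C/C(/C=C/c2ccccn2)=N/Oc2ncnc3cc(Cl)ccc23)c(Cl)c1`: 91.8%
Compound 2 `Clc1ccc2c(O/N=C(/C=C/c3ccc(OCc4ccccc4Cl)cc3)\C=C\c3ccccn3)ncnc2c1`: 84.7%
Compound 3 `Clc1ccc(COc2ccc(/C=C/C(/C=C/c3ccccn3)=N/Oc3ncnc4cc(Cl)ccc34)cc2)c(Cl)c1`: 23.6%

In a functional assay on SMMC-7721 cells (Homo sapiens) for inhibition, read by MTT assay, with a stated time of 72 h, tested at 10 uM (a lower number here means a weaker effect, a higher number a stronger effect of the compound at the concentration tested), compound 1 gives the highest of the three numbers. Compound 2 sits nearest, within the scatter, so the two cannot be ordered; compound 3 lies far beneath both, and its value against that of compound 1 shows a gap well beyond the scatter.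

Compound 4 `Fc1ccccc1COc1ccccc1/C=C/C(/C=C/c1ccccn1)=N/Oc1ncnc2cc(Cl)ccc12` is derived from compound 1 by a single change: 2-fluorophenyl in place of 2,4-dichlorophenyl on a saturated chain carbon bound to an oxygen on an aromatic ring. One chlorine is thus removed from the benzyl ring and the other gives way to fluorine.

Going by the values given here, only one measured step touches the same benzyl ring. There, a number 61.1 percentage points lower from compound 2 to compound 3 (beyond the scatter), and that step added a chlorine to the ring. The present change runs the other way, taking chlorine off, but it also moves from chlorine to fluorine and the central part of the core is not the same as in compounds 2 and 3, so the step cannot be simply mirrored. On that basis a small loss or no step beyond the scatter is expected in this assay, with a number 11.8 percentage points lower from compound 1 to compound 4 (beyond the scatter) as the estimated step.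

Compound 4 is therefore estimated at 80%, between 55% and 95%.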

Compound 4, a percentage reported as inhibition, at one concentration (the size of the read-out at that concentration, not a potency): 94.8%
For compound 4 the middle estimate is 14.8 percentage points below the measured one; measured number inside the range.
By their numbers in this assay, from the lowest: compound 3; then compounds 2, 1 and 4 (each within the scatter of the next, the first and the last beyond it).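

In this assay the exchange of 2,4-dichlorophenyl for 2-fluorophenyl on the saturated chain carbon gives a number 3 percentage points higher from compound 1 to compound 4 (within the scatter) and leaves the two compounds unordered, so on the core of compound 1 neither chlorine is needed to keep the read-out high at the concentration tested, and a single fluorine serves in their place. Going by these compounds alone, this differs from the only earlier step on this benzyl ring, a number 61.1 percentage points lower from compound 2 to compound 3 (beyond the scatter) and there one added chlorine cost much of the read-out, whereas here the ring loses both chlorines and no change beyond the scatter appears. Nothing measured in the material at hand accounts for this tolerance or for the contrast between the two steps.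

Within the data shown here, the single change in compound 4 removes one chlorine and swaps the other for fluorine, so the two parts cannot be told apart, and how a plain unsubstituted benzyl group, a 2-chlorobenzyl group or a methoxy group on this ring would read remains open. On these data alone, since the read-out comes from one concentration, it also remains open whether compound 1 and compound 4 would separate in the strength of their effect at other concentrations.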